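The source may report more compounds than this note shows. Statements on the series, on what has been measured and on what is new or still open speak of the compounds shown alone.

In a functional assay on HeLa cells (Homo sapiens) for antiproliferative activity, read by CCK-8 assay, with a stated time of 72 h, tested at 2 uM (a lower number here means a weaker effect, a higher number a stronger effect of the compound at the concentration tested), the three measured compounds gave:
compound 1 `Nc1ccccc1NC(=O)c1ccc(CSC(=S)N2CCN(C(c3ccccc3)c3ccccc3)CC2)cc1`: 8%
compound 2 `Nc1ccccc1NC(=O)c1ccc(CSC(=S)N2CCN(c3ccc(Cl)cc3)CC2)cc1`: 51.2%
compound 3 `Nc1ccccc1NC(=O)c1ccc(CSC(=S)N2CCc3ccccc32)cc1`: 38%

Compound 2 stands highest of these three numbers. Its nearest neighbour, compound 3, lies lower by a margin beyond the usual scatter, and compound 1 lies furthest below it, also beyond the scatter. Compound 4 `Nc1ccccc1NC(=O)c1ccc(CSC(=S)N2CCN(c3cccnc3)CC2)cc1` is not yet measured; it differs from compound 2 in one place: pyridin-3-yl in place of 4-chlorophenyl on an amine nitrogen in a ring. Within the data shown here, no measured pair covers this exact change, so the expectation rests on compound 2 alone. A step of moderate size downward, beyond the scatter, is expected in this assay. The step from compound 2 to compound 4 is estimated at a number 16.2 percentage points lower from compound 2 to compound 4 (beyond the scatter). Compound 4 is expected to give 35%, within 15% to 58%.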

Compound 4, a percentage reported as inhibition, at one concentration (the size of the read-out at that concentration, not a potency): 66.2%
Compound 4: the middle estimate sits 31.2 percentage points below what was measured; the measured number lies above the stated range.
By their numbers in this assay, from the lowest: compound 1; then compound 3; then compound 2; then compound 4.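

In this assay, pyridin-3-yl in place of 4-chlorophenyl on the amine nitrogen in the ring gives a number 15 percentage points higher from compound 2 to compound 4 (beyond the scatter). Among these compounds, this is the first pair here that differs in one place, and it shows that this position tolerates losing the chlorine and gaining a ring nitrogen, with the effect at the tested concentration rising rather than falling. Nothing available explains the rise.

The compounds shown leave open whether the ring nitrogen or the missing chlorine matters more, a question a plain phenyl group would help separate. From the compounds shown here alone, whether pyridin-4-yl or pyridin-2-yl would behave like pyridin-3-yl also remains open.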